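Lengthening the Basic Side Chain on a Shared Core

The source may hold more compounds than are shown below. What is called first, only, known or untested is meant among the compounds shown, and "the series" means these compounds.

Of the compounds shown here, three built on one core have been measured in a functional assay on HCT-116 cells (Homo sapiens) for cytotoxicity, read by MTT assay, with a stated time of 72 h; a higher number here means a weaker inhibitor, a lower number a stronger inhibitor. Compound 1 `O=C1c2c[n+]([O-])c3ccccc3c2C(=O)c2c1c1ccccc1n2Cc1cn([C@H]2O[C@H](CO)[C@@H](O)[C@H]2O)nn1` gives 710 nM, compound 2 `O=C1c2c[n+]([O-])c3ccccc3c2C(=O)c2c1c1ccccc1n2Cc1cn([C@@H]2C[C@H](O)[C@@H](CO)O2)nn1` gives 50 nM, and compound 3 `O=C1c2c[n+]([O-])c3ccccc3c2C(=O)c2c1c1ccccc1n2CCN1CCCC1` gives 270 nM, the second highest of the three numbers. Going by the values given here, the only step between compounds differing in one place, a 14-fold lower number from compound 1 to compound 2 (1.15 log units; beyond the scatter), concerns a hydroxy on a saturated ring carbon and leaves the side chain on the aromatic nitrogen untouched. Compound 4 `CN1CCN(CCCCCn2c3c(c4ccccc42)C(=O)c2c[n+]([O-])c4ccccc4c2C3=O)CC1` differs from compound 3 by 3-(4-methylpiperazin-1-yl)propyl in place of pyrrolidin-1-yl on a saturated chain carbon, two bonds along the chain from an aromatic nitrogen. Among the compounds with values here, no measured step bears on a change of this kind, so the data give no direction for it. The expected step, a 1.1-fold higher number from compound 3 to compound 4 (0.05 log units; within the scatter), is estimated to stay within the scatter. Compound 4 is therefore expected to give about 300 nM, between 100 nM and 900 nM.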

Compound 4, half-maximal inhibitory concentration: 1220 nM
Compound 4: the middle estimate sits 4.1-fold (0.61 log units) below what was measured; the measured number lies above the stated range.
By their numbers in this assay, from the lowest: compound 2; then compound 3; then compounds 1 and 4 (each within the scatter of the next).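

At the saturated chain carbon two bonds along the chain from an aromatic nitrogen, the swap of pyrrolidin-1-yl for 3-(4-methylpiperazin-1-yl)propyl proves not to be neutral in this assay (a 4.5-fold higher number from compound 3 to compound 4 (0.65 log units; beyond the scatter)). Going by these compounds alone, the earlier step, at a saturated ring carbon, said nothing about this side chain, so this is the first sign that it matters here. No evidence bears on the reason for this step.

Chain and ring change together here, so which of them goes with the higher number stays open. A 4-methylpiperazin-1-yl group on the ethyl chain of compound 3, or pyrrolidin-1-yl on the pentyl chain of compound 4, would separate the two.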